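From 2-nitrophenyl to 3-nitrophenyl: compound 3 to compound 4

The compounds below may be only part of what the source reports. "The series", "measured", "known", "first", "only" and "open" are said of these compounds alone.

In a functional assay on MCF7 cells (Homo sapiens) for cytotoxicity, read by MTT assay, with a stated time of 96 h (a higher number here means a weaker inhibitor, a lower number a stronger inhibitor), compound 3 `COc1cc(C(=O)c2cn(-c3ccc(N)cc3)cc2-c2ccccc2[N+](=O)[O-])cc(OC)c1OC` gives 53 nM, within the scatter of compound 1 `COc1cc(C(=O)c2cn(-c3ccccc3)cc2-c2cccc([N+](=O)[O-])c2)cc(OC)c1OC` at 50 nM, while compound 2 `COc1cc(C(=O)c2cn(-c3ccc(F)cc3)cc2-c2cccc([N+](=O)[O-])c2)cc(OC)c1OC` gives 440 nM. Compound 4 `COc1cc(C(=O)c2cn(-c3ccc(N)cc3)cc2-c2cccc([N+](=O)[O-])c2)cc(OC)c1OC` carries 3-nitrophenyl in place of 2-nitrophenyl on an aromatic carbon. For the measured compounds named here, the only measured step, an 8.8-fold higher number from compound 1 to compound 2 (0.94 log units; beyond the scatter), is a different change, fluoro in place of hydrogen, so no measured pair isolates this one. Compound 1, which also bears 3-nitrophenyl, gives 50 nM, so no shift beyond the scatter is expected in this assay. The expected step is a 1.3-fold lower number from compound 3 to compound 4 (0.12 log units; within the scatter), with its direction uncertain. Compound 4 is estimated at 40 nM, with an expected range of 10 nM to 200 nM.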

Compound 4, half-maximal inhibitory concentration: 260 nM
Compound 4: the middle estimate sits 6.5-fold (0.81 log units) below what was measured; the measured number lies above the stated range.
By their numbers in this assay, from the lowest: compounds 1 and 3 (each within the scatter of the next); then compounds 4 and 2 (each within the scatter of the next).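

The nitro placement counts once the 4-aminophenyl group is present: in this assay the change gives a 4.9-fold higher number from compound 3 to compound 4 (0.69 log units; beyond the scatter), and with 3-nitrophenyl kept, amino in place of hydrogen gives a 5.2-fold higher number from compound 1 to compound 4 (0.72 log units; beyond the scatter). Amino and fluoro do not separate, with a 1.7-fold lower number from compound 2 to compound 4 (0.23 log units; within the scatter), so with 3-nitrophenyl both stand on the higher side of the hydrogen of compound 1. No measurement on hand accounts for these shifts.

Open, as far as these compounds go, is whether the gap between 2-nitrophenyl and 3-nitrophenyl persists with hydrogen or fluoro in place of amino. Also open, from the compounds shown here alone, is how a dimethylamino or carboxylic acid group would compare with amino.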